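The source may hold more compounds than are shown below. What is called first, only, known or untested is meant among the compounds shown, and "the series" means these compounds.

In a functional assay on HCT-116 cells (Homo sapiens) for cytotoxicity (a higher number here means a weaker inhibitor, a lower number a stronger inhibitor), compound 1 (`COc1cc(N2CCC(C(=O)N3CCOCC3)CC2)ccc1Nc1nc(NC2CCCCC2)c2nc[nH]c2n1`) gives 50 nM, compound 2 (`COc1cc(N2CCC(CC(=O)N3CCOCC3)CC2)ccc1Nc1nc(NC2CCCCC2)c2nc[nH]c2n1`) gives 36 nM and compound 3 (`COc1cc(N2CCC(CC(=O)N3CCC(N(C)C)C3)CC2)ccc1Nc1nc(NC2CCCCC2)c2nc[nH]c2n1`) gives 59 nM, so compound 3 stands within the scatter of both others. Compound 4 (`COc1cc(N2CCC(C(=O)N3CC(O)C3)CC2)ccc1Nc1nc(NC2CCCCC2)c2nc[nH]c2n1`) carries (3-hydroxyazetidin-1-yl)carbonyl in place of ((3-(dimethylamino)pyrrolidin-1-yl)carbonyl)methyl on a saturated ring carbon. Going by the values given here, three measured steps bear on this change. Inserting the methyl link gave a 1.4-fold lower number from compound 1 to compound 2 (0.14 log units; within the scatter), exchanging the amide ring gave a 1.6-fold higher number from compound 2 to compound 3 (0.21 log units; within the scatter), and both changes together gave a 1.2-fold higher number from compound 1 to compound 3 (0.07 log units; within the scatter). All three stay within the scatter, although no 3-hydroxyazetidine amide has been measured here. The expected result is a 1.2-fold lower number from compound 3 to compound 4 (0.07 log units; within the scatter), with no step beyond the scatter. For compound 4 the estimated value is 50 nM, with an expected range of 20 nM to 125 nM.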

Compound 4, half-maximal inhibitory concentration: 50 nM
Compound 4: the middle estimate sits on the measured number at the digits printed, and the stated range covers the measured number.
By their numbers in this assay, from the lowest: compounds 2, 1, 4 and 3 (each within the scatter of the next).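

In this assay the step from the morpholine amide to the 3-hydroxyazetidine amide on the same carbonyl carbon shows that the amide ring can shrink to four members and carry a hydroxy group with the number held (no change at the digits printed from compound 1 to compound 4 (within the scatter)). The comparisons with the two methyl-linked amides also stay within the scatter (a 1.4-fold higher number from compound 2 to compound 4 (0.14 log units; within the scatter); a 1.2-fold lower number from compound 3 to compound 4 (0.07 log units; within the scatter)). Nothing given here explains this flat response. Open, from the compounds shown here alone, is whether an amide ring bearing a carboxylic acid, or a chain longer than the methyl link, would move the number beyond the scatter.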